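This account rests on a few compounds, and the source may have more. Where it says the series, first, only, none or still open, it means among the compounds named here.

Compound 1 `Cc1cc(C)n2nc(SCc3nnc(SCc4coc5ccccc5c4=O)n3N)nc2n1`: in a functional assay on MCF7 cells (Homo sapiens) for cytotoxicity, read by MTT assay, with a stated time of 72 h (a higher number here means a weaker inhibitor, a lower number a stronger inhibitor), compound 1 gives > 25000 nM, which is a limit of the assay rather than a number.
Compound 2 `Cc1nnc(SCc2cc(=O)c3ccccc3o2)s1`: compound 2 gives > 25000 nM, again a limit of the assay.
Compound 3 `Cc1ccc2oc(CSc3nc4nc(C)cc(C)n4n3)cc(=O)c2c1`: compound 3 gives > 25000 nM, also a limit of the assay.

Compound 2 thus stands where every compound measured here stands: at the limit of > 25000 nM in this assay, at which 3 of the 3 values shown sit. Within the data shown here, no ranking among the three is possible, and no step between measured compounds can be read from such values.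

Compound 4 `Nc1nnc(SCc2cc(=O)c3ccccc3o2)s1` differs from compound 2 in one place: amino in place of methyl on an aromatic carbon. Among the measured compounds shown here, since none of the measured compounds gives a number, there is no measured step in this assay on which to build, and a change of this small size is not expected to move the value beyond the scatter in either direction; most likely compound 4 also ends at the limit. The step from compound 2 to compound 4 is therefore expected to be a step that the limit leaves unreadable from compound 2 to compound 4. For compound 4 the estimate is 30000 nM, between 10000 nM and 100000 nM.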

Compound 4, half-maximal inhibitory concentration: > 25000 nM
Compound 4: only a limit was reported; the forecaster's own chance of this, stated with the estimate: 75%; the middle value lies beyond the limit too.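

Compound 2 and compound 4 each give only a limit of the assay rather than a number, so no step can be read from the change of methyl to amino: the limit of > 25000 nM in this assay, at which 4 of the 4 values shown sit.

The compounds shown leave open how strongly any of them acts in this assay, and which change in structure would bring a value into measurable range.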